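From 4-acetylpiperazin-1-yl to 1-acetylpiperidin-4-yl

This account rests on a few compounds, and the source may have more. Where it says the series, first, only, none or still open, it means among the compounds named here.

Compound 1 `CC(=O)N1CCN(C(=O)N2Cc3c(NC(=O)c4ccc(F)cc4)n[nH]c3C2(C)C)CC1` gives > 10000 nM in a functional assay on A2780 cells (Homo sapiens) for antiproliferative activity, read by fluorescence, with a stated time of 72 h (on this read-out higher numbers stand for weaker inhibition and lower numbers for stronger inhibition), as a limit, not a number. Compound 2 `CN(C)CC(=O)Nc1n[nH]c2c1CN(C(=O)C(C)(C)C)C2(C)C` gives a measured 580 nM in this assay on the same read-out. Compound 3 `CC(=O)N1CCC(C(=O)N2Cc3c(NC(=O)c4ccc(F)cc4)n[nH]c3C2(C)C)CC1` keeps the rest of compound 1 and carries 1-acetylpiperidin-4-yl in place of 4-acetylpiperazin-1-yl on a carbonyl carbon. Among the measured compounds shown here, no measured pair covers this change, so only a small move is expected. The expected at least 1.1-fold lower number from compound 1 to compound 3 (0.04 log units; that floor lies within the scatter) points towards stronger inhibition if it exceeds the scatter at all. For compound 3 the estimated value is 9000 nM with an expected range from 2500 nM to 30000 nM in this series.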

Compound 3, half-maximal inhibitory concentration: > 10000 nM
Compound 3: no number, only a limit (the forecaster's own chance of this, stated with the estimate: 55%); middle value at least 1.1-fold (0.04 log units) away from the limit.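

No step can be read from compound 1 to compound 3, since both stand only as limits, not numbers: the limit of > 10000 nM in this assay, at which 2 of the 3 values shown sit.

Whether 1-acetylpiperidin-4-yl or 4-acetylpiperazin-1-yl on a carbonyl carbon gives the stronger inhibition stays open in the compounds shown.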